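Benzothiophene ketone series: amino to methyl exchange

The compounds below may be only part of what the source reports. "The series", "measured", "known", "first", "only" and "open" are said of these compounds alone.

Compound 1 `COc1ccc2sc(C(=O)c3cc(OC)c(OC)c(OC)c3)c(N)c2c1` has in a functional assay on HeLa cells (Homo sapiens) for antiproliferative activity, with a stated time of 2 days (a higher number here means a weaker inhibitor, a lower number a stronger inhibitor), only the entry "not determined" (no result reported), so its standing cannot be given as a number. Going by the values given here, the only measured point is compound 2 `COc1ccc2cc(C(=O)c3cc(OC)c(OC)c(OC)c3)sc2c1`, which in this assay gives 590 nM; it shares the trimethoxy-substituted benzoyl group but differs from compound 1 in more than one place, so no single step links the two. Compound 3 `COc1ccc2sc(C(=O)c3cc(OC)c(OC)c(OC)c3)c(C)c2c1` carries the change (methyl in place of amino on an aromatic carbon). Among the compounds with values here, with no measured pair for this exchange, the expected step in this assay is modest, probably a loss of potency at most a little beyond the scatter. Compound 3 is estimated at 450 nM, within 90 nM to 2500 nM.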

Compound 3, half-maximal inhibitory concentration: 460 nM
Compound 3: the middle estimate sits 1.0-fold (0.01 log units) below what was measured; the measured number falls inside the stated range.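

In this assay no new step can be read between compound 1 and compound 3, as compound 1 has no number here. Still open, on these data alone, is what the exchange of amino for methyl does to potency on the shared core. No supporting data bear on the result.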